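The source may hold more compounds than are shown below. What is called first, only, known or untested is meant among the compounds shown, and "the series" means these compounds.

Measured so far:
compound 1, `CC1(C)CCC[C@]2(C)[C@@H](CC[C@@](C)(O)/C=C/c3cccc([N+](=O)[O-])c3)[C@](C)(O)CC[C@@H]12`: 3380 nM
compound 2, `Cc1cccc(/C=C/[C@](C)(O)CC[C@@H]2[C@@]3(C)CCCC(C)(C)[C@@H]3CC[C@@]2(C)O)c1C`: 3700 nM
compound 3, `CC1(C)CCC[C@]2(C)[C@@H](CC[C@@](C)(O)/C=C/c3ccc(Cl)nc3)[C@](C)(O)CC[C@@H]12`: 3680 nM

All three were measured in a functional assay on HeLa cells (Homo sapiens) for cytotoxicity, read by MTT assay, with a stated time of 48 h; a higher number here means a weaker inhibitor, a lower number a stronger inhibitor. They share one core and differ only in the aromatic group on a double-bonded chain carbon bound to a double-bonded chain carbon. Among the compounds with values here, compound 2 gives the highest of the three numbers, but its nearest neighbour is compound 3, a 1.0-fold lower number from compound 2 to compound 3 (0.00 log units; within the scatter), and its furthest is compound 1, a 1.1-fold higher number from compound 1 to compound 2 (0.04 log units; within the scatter); no pair here is separated by more than the scatter, so the three stand level.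

Compound 4, `CC1(C)CCC[C@]2(C)[C@@H](CC[C@@](C)(O)/C=C/c3ccc(C(=O)O)cc3)[C@](C)(O)CC[C@@H]12`, has not yet been measured in this assay. It differs from compound 2 as follows:
4-carboxyphenyl in place of 2,3-dimethylphenyl on a double-bonded chain carbon bound to a double-bonded chain carbon

Within the data shown here, the steps that bear on this change are the two aryl exchanges at the same place: a 1.1-fold higher number from compound 1 to compound 2 (0.04 log units; within the scatter) and a 1.0-fold lower number from compound 2 to compound 3 (0.00 log units; within the scatter). Both are within the scatter, though neither replacement brought in a hydrogen-bond donor or acceptor as the 4-carboxyphenyl does. On the three compounds measured, the aryl group appears to make no difference beyond the scatter, so for compound 4 a step of a 1.1-fold higher number from compound 2 to compound 4 (0.03 log units; within the scatter) is expected, that is, none beyond the scatter. Compound 4 is thus estimated at 4000 nM, with a range from 1800 nM to 9000 nM.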

Compound 4, half-maximal inhibitory concentration: 45400 nM
Beside the measured number, compound 4's estimate is 11-fold (1.05 log units) below it; the whole stated range lies below it.
By their numbers in this assay, from the lowest: compounds 1, 3 and 2 (each within the scatter of the next); then compound 4.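

In this assay this position, on a double-bonded chain carbon bound to a double-bonded chain carbon, is not indifferent to the aryl group: 4-carboxyphenyl gives a 12-fold higher number from compound 2 to compound 4 (1.09 log units; beyond the scatter) in place of 2,3-dimethylphenyl, and the steps from the other two aryl compounds are of the same order, a 12-fold higher number from compound 3 to compound 4 (1.09 log units; beyond the scatter) and a 13-fold higher number from compound 1 to compound 4 (1.13 log units; beyond the scatter) as read against 6-chloropyridin-3-yl and 3-nitrophenyl. The level standing of compounds 1, 2 and 3 therefore holds for those three aryl groups only, not for the position as a whole, and all three large steps lead to the same compound, so the loss rests on compound 4 alone. Nothing measured here accounts for the size of this step.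

The compounds shown leave open whether the step belongs to the carboxylic acid as such or to other features of the 4-carboxyphenyl group, a question that a methyl ester or a primary amide on the same phenyl ring could address. They also leave open how an amine at this place would compare in this cell read-out.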